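Tetrazole for Fluoro: the Step from Compound 1 to Compound 3

The source may hold more compounds than are shown below. What is called first, only, known or untested is meant among the compounds shown, and "the series" means these compounds.

Measured so far:
compound 1, `Fc1ccc(-c2nc3cccnc3n2C2CCCC2)cc1`: 500 nM
compound 2, `COc1ccc(-c2nc3cccnc3n2C2CCCC2)cn1`: 219 nM

In a functional assay on MDA-MB-231 cells (Homo sapiens) for cytotoxicity, read by MTT assay, with a stated time of 24 h (on this read-out lower numbers stand for stronger inhibition and higher numbers for weaker inhibition), compound 1 gives 500 nM, the highest of the two numbers shown, while compound 2 gives 219 nM, a gap beyond the scatter. Compound 3, `c1cnc2c(c1)nc(-c1ccc(-c3nnn[nH]3)cc1)n2C1CCCC1`, has not been measured. It differs from compound 1 by 1H-tetrazol-5-yl in place of fluoro on an aromatic carbon. Among the compounds with values here, no measured pair shows such a change, so the size of the step is open. Compound 3 is expected to give a somewhat higher number than compound 1, a step of a 1.8-fold higher number from compound 1 to compound 3 (0.26 log units; within the scatter) that may not exceed the scatter. The estimate for compound 3 is 900 nM, with a range from 250 nM to 3500 nM.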

Compound 3, half-maximal inhibitory concentration: 765 nM
Beside the measured number, compound 3's estimate is 1.2-fold (0.07 log units) above it; the range from low to high includes it.
By their numbers in this assay, from the lowest: compound 2; then compounds 1 and 3 (each within the scatter of the next).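

In this assay, 1H-tetrazol-5-yl in place of fluoro, para to a large group, gives a 1.5-fold higher number from compound 1 to compound 3 (0.18 log units; within the scatter), the first step measured at this position. The position therefore accepts a far larger group, carrying a five-membered aromatic ring with a hydrogen-bond donor and hydrogen-bond acceptors, with no step beyond the scatter. Nothing shown bears on why the step has this size.

Going by these compounds, whether a carboxylic acid or an amine at this position would give a number close to that of compound 1 remains open. So does the outcome for a longer chain ending in 1H-tetrazol-5-yl.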